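This account rests on a few compounds, and the source may have more. Where it says the series, first, only, none or still open, it means among the compounds named here.

The measured compounds and their values:

compound 1, `O=C(CN1C(=O)NC2(C1=O)c1ccccc1-c1ccccc12)Nc1ccc(Cl)cc1`, 80.4%;
compound 2, `O=C(CN1C(=O)NC2(CCCCC2)C1=O)Nc1ccc(Br)cc1`, 85.1%;
compound 3, `Cc1ccc(NC(=O)CN2C(=O)NC3(CCCCC3)C2=O)cc1`, 70.3%.

All three were tested in a functional assay on the whole organism (strain BALB/c) with Mus musculus as the target, with a stated time of 8 h, at a dose of 10 mg/kg; on this read-out higher numbers stand for more inhibition at the one dose given (going by the name of the read-out) and lower numbers for less inhibition. Compound 3 stands lowest of the three: compound 1 sits higher, and compound 2 sits higher still, both by more than the usual scatter. Within the data shown here, the one single-point step among them runs from compound 2 to compound 3, where the change is methyl in place of bromo on an aromatic carbon, and it reads a number 14.8 percentage points lower from compound 2 to compound 3 (beyond the scatter).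

Compound 4, `COc1ccc(NC(=O)CN2C(=O)NC3(CCCCC3)C2=O)cc1`, has not yet been measured. It differs from compound 3 by methoxy in place of methyl on an aromatic carbon. Among the measured compounds shown here, the only step that touches the same place is the one from compound 2 to compound 3, and that step shows a modest drop when methyl replaced bromo there. For the measured compounds named here, no measured pair shows methoxy against methyl, so the direction of the new step cannot be read from the data; the change is small in size, and a step of no more than the scatter in this assay is the plainest expectation.

Compound 4 is therefore expected to give about 72%, within a range of 55% to 88%, which amounts to an expected step of a number 1.7 percentage points higher from compound 3 to compound 4 (within the scatter).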

Compound 4, a percentage reported as inhibition, in the whole organism at one dose (the size of the read-out at that dose, not a potency): 56.1%
For compound 4 the middle estimate is 15.9 percentage points above the measured one; measured number inside the range.
By their numbers in this assay, from the lowest: compound 4; then compound 3; then compounds 1 and 2 (each within the scatter of the next).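

In this assay, methoxy in place of methyl on the aromatic carbon is not a silent swap, even though the two groups look much alike on paper: it gives a number 14.2 percentage points lower from compound 3 to compound 4 (beyond the scatter). Read together with the earlier a number 14.8 percentage points lower from compound 2 to compound 3 (beyond the scatter) and the new a number 29 percentage points lower from compound 2 to compound 4 (beyond the scatter), this place shows a graded order among three compounds that share one core and differ only here, with bromo giving the highest number, methyl the middle one and methoxy the lowest, so the read-out responds to more than the loss of bromo alone. Nothing measured here explains why these groups fall in this order.

Going by these compounds, three groups at one place give an order but not a rule, so it remains open where an amine, a carboxylic acid or a longer chain such as ethoxy would fall on the 4-substituted phenyl ring. On these data alone, it is also open whether the same order would hold on the core of compound 1, which differs from these compounds in more than one place and so cannot be compared with them directly.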